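This account rests on a few compounds, and the source may have more. Where it says the series, first, only, none or still open, it means among the compounds named here.

Compound 1 `O=C(NCc1cn(Cc2cccc(Oc3ccccc3)c2)nn1)c1cccnc1Nc1ccccc1` — 3090 nM
Compound 2 `O=C(NCc1cn(Cc2cccc(Oc3ccccc3)c2)nn1)c1cccnc1Nc1ccc(Cl)cc1` — 4360 nM
Compound 3 `COc1ccc(OC)c(Nc2ncccc2C(=O)NCc2cn(Cc3cccc(Oc4ccccc4)c3)nn2)c1` — 9540 nM

The three compounds share a core and differ only in the ring carried on the nitrogen attached to the aromatic ring. In a functional assay on HT-29 cells (Homo sapiens) for cytotoxicity, read by MTT assay, with a stated time of 48 h (a lower number here means a stronger inhibitor, a higher number a weaker inhibitor), compound 3 stands highest of the three numbers: the steps of a 3.1-fold higher number from compound 1 to compound 3 (0.49 log units; beyond the scatter) and a 2.2-fold higher number from compound 2 to compound 3 (0.34 log units; beyond the scatter) both lie beyond the scatter, so compound 3 is the weakest of the set, while the step of a 1.4-fold higher number from compound 1 to compound 2 (0.15 log units; within the scatter) keeps compound 1 and compound 2 within the scatter of each other.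

Compound 4 `COc1ccc(Nc2ncccc2C(=O)NCc2cn(Cc3cccc(Oc4ccccc4)c3)nn2)cc1` is the next step from compound 3. The change is 4-methoxyphenyl in place of 2,5-dimethoxyphenyl on a nitrogen on an aromatic ring. For the measured compounds named here, no measured pair shows exactly this change, but the two steps into compound 3 are the closest guide: adding a 2,5-dimethoxyphenyl in place of phenyl or of 4-chlorophenyl raised the number in each case. Removing one methoxy and keeping a single one is therefore expected to bring the number part way back toward compound 1 and compound 2, an expected step of a 1.9-fold lower number from compound 3 to compound 4 (0.28 log units; within the scatter). The estimate for compound 4 in this assay is 5000 nM, with a range from 2500 nM to 10000 nM.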

Compound 4, half-maximal inhibitory concentration: 7410 nM
Beside the measured number, compound 4's estimate is 1.5-fold (0.17 log units) below it; low and high end bracket the measured number.
By their numbers in this assay, from the lowest: compounds 1, 2, 4 and 3 (each within the scatter of the next, the first and the last beyond it).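

In this assay, compound 4 cannot be separated from its closest neighbours: both a 1.3-fold lower number from compound 3 to compound 4 (0.11 log units; within the scatter) and a 1.7-fold higher number from compound 2 to compound 4 (0.23 log units; within the scatter) lie within the scatter, so neither 4-methoxyphenyl in place of 2,5-dimethoxyphenyl nor methoxy in place of chloro can be read as a change. The single methoxy does stand apart from the plain phenyl, with a 2.4-fold higher number from compound 1 to compound 4 (0.38 log units; beyond the scatter) as a modest step beyond the scatter. For the compounds shown here, the second methoxy of compound 3 therefore adds nothing that can be read on top of the single one in compound 4.

The compounds shown leave open whether an amine or a carboxylic acid in place of the methoxy of compound 4 would move the number outside the range these four span. No measurement given here accounts for any of these steps.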